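Bromocatechol benzyl alcohols: methyl ether effect on cytotoxicity

A few compounds are considered here, and "the series" means these few. Any claim that something is new, unique, unknown or untested is made for them only; others in the source may bear on it.

Measured compounds:
- compound 1, `OCc1cc(Br)c(O)c(O)c1Br`: 21400 nM
- compound 2, `COCc1cc(Br)c(O)c(O)c1Br`: 3480 nM
- compound 3, `OCc1cc(O)c(O)c(Br)c1Br`: 20400 nM

All three were tested in a functional assay on HCT-116 cells (Homo sapiens) for cytotoxicity, read by MTT assay, with a stated time of 96 h; a lower number here means a stronger inhibitor, a higher number a weaker inhibitor. Compound 1 gives 21400 nM in this assay, and compound 3 gives 20400 nM; the two numbers lie within the scatter of each other, so no order between them is claimed. Compound 1 and compound 3 have the same atoms joined differently, and the difference between the two cores is not broken down here.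

Within the data shown here, the one step so far is a 6.1-fold lower number from compound 1 to compound 2 (0.79 log units; beyond the scatter). The change behind it is methyl in place of hydrogen on an oxygen on a saturated carbon. Compound 2 gives 3480 nM in this assay.

The unmeasured compound 4, `COCc1cc(O)c(O)c(Br)c1Br`, stands to compound 3 as compound 2 stands to compound 1. The change is methyl in place of hydrogen on an oxygen on a saturated carbon. The place is the same in both pairs, so this is the same change, seen once before in the series. Among the measured compounds shown here, its only precedent is the step from compound 1 to compound 2, and the expectation rests on that single step together with the near-identical numbers of compound 1 and compound 3.

Compound 4 is therefore expected to give about 4000 nM in this assay, with the estimated range running from 1500 nM to 12000 nM. For the measured compounds named here, that estimate means a step of a 5.1-fold lower number from compound 3 to compound 4 (0.71 log units; beyond the scatter), expected to be of a size close to the earlier one; with only one precedent, the range is kept wide.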

Compound 4, half-maximal inhibitory concentration: 14100 nM
Estimate against measurement, compound 4: 3.5-fold (0.55 log units) below; measured number outside the range, above it.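

In this assay, the same methyl-for-hydrogen change on the oxygen of the hydroxymethyl group gives a 1.4-fold lower number from compound 3 to compound 4 (0.16 log units; within the scatter), so the step seen on the core of compound 1 does not carry over at the same size to the core of compound 3. The two steps are set side by side here, and the gap between them is real at this level of scatter: the same change on two cores in this assay, a 6.1-fold lower number (0.79 log units; beyond the scatter) from compound 1 to compound 2 and a 1.4-fold lower number (0.16 log units; within the scatter) from compound 3 to compound 4, 4.3-fold (0.63 log units) apart, beyond the scatter of two such steps. This shows that, in these two pairs, the effect of going from hydroxymethyl to methoxymethyl cannot be transferred from one core to the other as a fixed increment, but with a single pair on each core it does not show which feature of the two cores accounts for the difference, or whether other changes at this place would diverge in the same way.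

Still open, from the compounds shown here alone, is how the two cores would respond to a longer chain on that oxygen, such as an ethyl or propyl ether. Equally open, going by these compounds, is whether an amine or a carboxylic acid in place of the hydroxymethyl group would separate the two cores as the methyl ether does.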